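Swapping isopropyl for an ester chain on the nitrogen

The source may hold more compounds than are shown below. What is called first, only, known or untested is meant among the compounds shown, and "the series" means these compounds.

Compound 1 `C/N=C(/S)[C@]1(c2cccnc2)CCCC[S@@+]1[O-]`: 700 nM; 400 nM; > 30000 nM (3 entries)
Compound 2 `CC(C)/N=C(\S)[C@]1(c2cccnc2)CCCC[S+]1[O-]`: 10000 nM

For the measured compounds named here, in a functional assay (aorta) for inhibition, with Rattus norvegicus as the target (on this read-out lower numbers stand for stronger inhibition and higher numbers for weaker inhibition), compound 2 gives 10000 nM, its only number, and one further entry offers no single number. That number is higher than the two plain numbers of compound 1, which puts compound 2 on the weaker side of those two readings. The entries of compound 1 are the several entries of compound 1 in this assay, 700 nM; 400 nM; > 30000 nM (3 entries), and the last of these is a limit of the assay, not a number.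

The next compound, compound 3 `COC(=O)CC/N=C(\S)[C@]1(c2cccnc2)CCCC[S+]1[O-]`, has 2-(methoxycarbonyl)ethyl in place of isopropyl on a double-bonded nitrogen, and the rest of the structure stays the same: 2-(methoxycarbonyl)ethyl in place of isopropyl on a double-bonded nitrogen.

Going by the values given here, no measured step between two compounds is available to show what such a swap does. The expectation for this assay therefore leans on compound 2, at 10000 nM. The estimated step of a 1.2-fold higher number from compound 2 to compound 3 (0.08 log units; within the scatter) stays within the usual scatter, with no clear direction expected. Compound 3 is estimated at 12000 nM, with an expected range from 3000 nM to 30000 nM.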

Compound 3, concentration for 90% inhibition: > 30000 nM
Compound 3 was reported as a limit; the forecaster's own chance of this, stated with the estimate: 35%; middle value at least 2.5-fold (0.39 log units) away from the limit.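

On the double-bonded nitrogen, 2-(methoxycarbonyl)ethyl in place of isopropyl gives an at least 3.0-fold higher number from compound 2 to compound 3 (0.47 log units; beyond the scatter) in this assay. For the compounds shown here, this is the first measured step at this position, and it shows that the position does not accept this change without a loss of inhibition, a drop that the estimate, resting on compound 2 alone, could not reveal. The reading for compound 3 is a limit of the assay, not a number, so the step gives only a minimum size, and compound 1 shows that a reading at this limit can also occur among entries that otherwise carry plain numbers: the several entries of compound 1 in this assay, 700 nM; 400 nM; > 30000 nM (3 entries)

As far as these compounds go, how much inhibition, if any, remains in compound 3 stays open, and so does the question of which part of the new group matters, the length of the chain or the ester at its end. A plain butyl chain would speak to length alone, while a carboxylic acid or an amide at the end of the same chain would speak to the ester.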